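The source may report more compounds than this note shows. Statements on the series, on what has been measured and on what is new or still open speak of the compounds shown alone.

Measured so far in a functional assay on IMR-32 cells (Homo sapiens) for cytotoxicity, read by sulforhodamine B assay, with a stated time of 48 h (a lower number here means a stronger inhibitor, a higher number a weaker inhibitor), as the only read-out:
- compound 1 `CC(=O)N1N=C(c2ccco2)CC1c1cccc(O)c1` gives 11800 nM
- compound 2 `O=CCN1N=C(c2ccc3ccccc3c2)CC1c1ccccc1[N+](=O)[O-]` gives 3360 nM

Compound 2 holds the lower of the two numbers, and the gap to compound 1 lies beyond the scatter. Within the data shown here, these two compounds differ in more than one place, so no measured pair isolates a single change.

The next compound, compound 3 `COc1ccc(C2CC(c3ccc4ccccc4c3)=NN2CC=O)cc1`, has 4-methoxyphenyl in place of 2-nitrophenyl on a saturated ring carbon. Nothing measured tests this swap directly. Among the measured compounds shown here, with compound 2 at 3360 nM already the lower of only two numbers, a small move toward a higher number in this assay is the more likely direction, near the edge of the scatter. The expected change is (a 1.4-fold higher number from compound 2 to compound 3 (0.15 log units; within the scatter)). In this assay compound 3 is estimated at 4800 nM with an expected range from 1600 nM to 14000 nM for now.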

Compound 3, half-maximal inhibitory concentration: 4120 nM
Compound 3: middle estimate off by 1.2-fold (0.07 log units), on the high side, and the stated range covers the measured number.
By their numbers in this assay, from the lowest: compounds 2 and 3 (each within the scatter of the next); then compound 1.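

Among these compounds, the first single-place comparison, 4-methoxyphenyl in place of 2-nitrophenyl on a saturated ring carbon, gives in this assay a 1.2-fold higher number from compound 2 to compound 3 (0.09 log units; within the scatter) with the rest of the structure unchanged. At this position, then, the two aryl groups cannot be told apart in this assay, although both the substituent and its place on the phenyl ring change in the same step, so this single pair cannot separate those two changes. Nothing on hand bears on what lies behind this result.

Still open, as far as these compounds go, is whether 4-nitrophenyl or 2-methoxyphenyl at this position would separate the substituent from its place on the ring, and whether an aminophenyl or carboxyphenyl group would move the number beyond the scatter. Also open, from the compounds shown here alone, is what a longer chain in place of the formylmethyl group would do.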